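Aryl imine swap on the shared core: chloro to hydroxy

The source may report more compounds than this note shows. Statements on the series, on what has been measured and on what is new or still open speak of the compounds shown alone.

Measured so far:
- compound 1 `COc1ccccc1/C=N/c1c(C)n(C)n(-c2ccccc2)c1=O` in a functional assay on HCT-116 cells (Homo sapiens) for cytotoxicity, read by MTT assay, with a stated time of 72 h; on this read-out lower numbers stand for stronger inhibition and higher numbers for weaker inhibition: 324000000 nM
- compound 2 `Cc1c(/N=C/c2ccc(Cl)cc2)c(=O)n(-c2ccccc2)n1C` in this assay: 589000000 nM

Compound 2 gives the highest of the two numbers in this assay, but its nearest neighbour is compound 1, and the step of a 1.8-fold higher number from compound 1 to compound 2 (0.26 log units; within the scatter) lies within the scatter, so the two compounds cannot be ordered on this read-out.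

Compound 3 `Cc1c(/N=C/c2ccc(O)cc2)c(=O)n(-c2ccccc2)n1C` has not been measured. It differs from compound 2 by hydroxy in place of chloro on an aromatic carbon. Among the measured compounds shown here, the only measured step, a 1.8-fold higher number from compound 1 to compound 2 (0.26 log units; within the scatter), also alters the substituent on the aryl ring attached to the imine carbon, and it did not move the number beyond the scatter. For the measured compounds named here, no measured step tests a hydroxy group in this position, so nothing in the data points to a direction for compound 3.

On that basis compound 3 is expected to land close to compound 2, with the estimated step of a 1.2-fold lower number from compound 2 to compound 3 (0.07 log units; within the scatter) not exceeding the usual scatter. The estimate for compound 3 in this assay is 500000000 nM, with a range from 200000000 nM to 1500000000 nM.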

Compound 3, half-maximal inhibitory concentration: 646000000 nM
Compound 3: middle estimate off by 1.3-fold (0.11 log units), on the low side; measured number inside the range.
By their numbers in this assay, from the lowest: compounds 1, 2 and 3 (each within the scatter of the next).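

In this assay, hydroxy in place of chloro on an aromatic carbon, para to a large group, gives a 1.1-fold higher number from compound 2 to compound 3 (0.04 log units; within the scatter), so a hydrogen-bond donor and acceptor entering at this position, where the chloro group has neither, does not move the number beyond the scatter. Set against the 2-methoxyphenyl group of compound 1, the 4-hydroxyphenyl group gives a 2.0-fold higher number from compound 1 to compound 3 (0.30 log units; within the scatter), which is also printed as within the scatter, so the three aryl groups on the imine carbon cannot be ordered on this read-out. No supporting data are available to explain this flat result.

From the compounds shown here alone, it remains open whether an amine, a carboxylic acid or a longer alkoxy chain on this aryl ring would give a step beyond the scatter in this assay. Going by these compounds, the effect of any change to the shared core outside this aryl group also remains open, as all three compounds carry that core unchanged.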